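A Phenoxypropyl Ester Expected to Rejoin the Weak Pack

This account rests on a few compounds, and the source may have more. Where it says the series, first, only, none or still open, it means among the compounds named here.

Three esters on a shared crown-ether core have been tested in a functional assay on HeLa cells (Homo sapiens) for inhibition, read by sulforhodamine B assay, with a stated time of 48 h; a higher number here means a weaker inhibitor of growth, a lower number a stronger inhibitor of growth. Compound 1 `O=C(CCCCCc1ccccc1)OCC1COCCOCCOCCOCCOCCO1` gives 79000 nM, and compound 2 `O=C(CCCCC1CCCCC1)OCC1COCCOCCOCCOCCOCCO1` gives 71000 nM; the step of a 1.1-fold lower number from compound 1 to compound 2 (0.05 log units; within the scatter) is small. Compound 3 `CC/C=C/CC(=O)OCC1COCCOCCOCCOCCOCCO1` reaches only the limit of this assay, > 100000 nM, so for compound 3 no number is known and it stands at the weak end of what was measured, among (the limit of > 100000 nM in this assay, at which 1 of the 3 values shown sits).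

Compound 4 `O=C(CCCCOc1ccccc1)OCC1COCCOCCOCCOCCOCCO1` differs from compound 3 by 3-phenoxypropyl in place of but-1-en-1-yl on a saturated chain carbon bound to a carbonyl carbon. The measured steps that bear on this change are the reverse of those leading into compound 3: an at least 1.2-fold higher number from compound 1 to compound 3 (0.10 log units; that floor lies within the scatter) and an at least 1.4-fold higher number from compound 2 to compound 3 (0.14 log units; that floor lies within the scatter), both only floors and both within the scatter. Replacing the short unsaturated chain with a longer chain bearing a ring has so far brought compounds back from the limit to measurable values, so compound 4 is expected to land near compound 1 and compound 2, a step of an at least 1.3-fold lower number from compound 3 to compound 4 (0.12 log units; that floor lies within the scatter). Compound 4 is therefore estimated at 75000 nM, within a range from 40000 nM to 150000 nM.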

Compound 4, concentration for 50% growth inhibition: > 100000 nM
Compound 4 ended at the assay's limit (the forecaster's own chance of this, stated with the estimate: 30%); middle value at least 1.3-fold (0.12 log units) away from the limit.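

In this assay compound 4 gives > 100000 nM, a limit of the assay and not a number, so a longer chain ending in a ring does not by itself give a readable value at this position. Phenoxy in place of benzyl gives an at least 1.2-fold higher number from compound 1 to compound 4 (0.10 log units; that floor lies within the scatter), and phenoxy in place of cyclohexyl gives an at least 1.4-fold higher number from compound 2 to compound 4 (0.14 log units; that floor lies within the scatter), so neither swap can be told from no change at all. The steps between the two compounds at the limit cannot be read, and the weak end of the series fills up: the limit of > 100000 nM in this assay, at which 2 of the 4 values shown sit.

On these data alone, every readable step here stays within the scatter, so it remains open whether this position can shift growth inhibition at all. An amine or a carboxylic acid at the end of the chain, or a much longer chain, could test that, and the compounds shown say nothing about such groups.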